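The source may report more compounds than this note shows. Statements on the series, on what has been measured and on what is new or still open speak of the compounds shown alone.

Compound 1 `CCCc1nc2c(C)ccnc2n1Cc1ccc(OC(C(=O)O)c2ccccc2)cc1`: 3400 nM
Compound 2 `CCc1nc2c(C)cc(C)nc2n1Cc1ccc(OC(C(=O)O)c2ccccc2)c(C)c1`: 940 nM

In an assay on Midbrain with Type-2 angiotensin II receptor (Rattus norvegicus) as the target (a lower number here means a stronger inhibitor, a higher number a weaker inhibitor), compound 2 gives the lower of the two numbers; the gap to compound 1 is beyond the usual scatter, so compound 2 is the stronger inhibitor of the pair. Compound 3 `CCc1nc2c(C)cc(C)nc2n1Cc1ccc(OC(C(=O)O)c2ccccc2)c(C(C)C)c1` is the next compound to be measured. It differs from compound 2 by isopropyl in place of methyl on an aromatic carbon. Among the compounds with values here, no measured pair shows a change of this kind, so there is no direct guide to its effect. The expectation is a small step of a 1.4-fold higher number from compound 2 to compound 3 (0.14 log units; within the scatter) toward a weaker inhibitor, not clearly beyond the scatter. Compound 3 is therefore estimated at 1300 nM in this assay, within a range from 400 nM to 4500 nM.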

Compound 3, half-maximal inhibitory concentration: 3300 nM
Estimate against measurement, compound 3: 2.5-fold (0.40 log units) below; the range from low to high includes it.
By their numbers in this assay, from the lowest: compound 2; then compounds 3 and 1 (each within the scatter of the next).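

Within the data shown here, replacing methyl with isopropyl on this aromatic carbon gives a 3.5-fold higher number from compound 2 to compound 3 (0.55 log units; beyond the scatter) in this assay, the first direct reading of a change at this position. The position is therefore not indifferent to its substituent: of these two groups, methyl goes with the stronger inhibitor, though one pair sets no trend. Nothing available explains why the number rises. Still open, going by these compounds, is whether ethyl would fall between these two groups, and whether a methoxy group or an amine on this carbon would give a stronger inhibitor than compound 2.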